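The compounds below may be only part of what the source reports. "The series", "measured", "known", "first", "only" and "open" are said of these compounds alone.

Measured compounds:
- compound 1 `CC1=C(C(=O)OCC2CCC2)C(c2ccco2)NC(=O)N1`: 1%
- compound 2 `CC1=C(C(=O)OCC2CCC2)C(c2ccoc2)NC(=O)N1`: 2%
- compound 3 `CCC(C)OC(=O)C1=C(C)NC(=O)NC1c1ccsc1`: 7%

In an assay on membranes from HeLa cells for displacement of a labelled ligand from adenosine receptor A3 (Homo sapiens), read by scintillation counting, with a stated time of 180 min, tested at 1 uM (on this read-out higher numbers stand for more inhibition at the one concentration tested (going by the name of the read-out) and lower numbers for less inhibition), all three measured compounds give low numbers. Compound 3 has the highest of the three, but its gaps to compound 2 and to compound 1 both lie within the scatter. Within the data shown here, the only single-place step measured, a number 1 percentage points higher from compound 1 to compound 2 (within the scatter), also lies within the scatter.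

Compound 4 `CC1=C(C(=O)OCC2CCC2)C(c2ccsc2)NC(=O)N1` differs from compound 3 by cyclobutylmethyl in place of sec-butyl on an oxygen next to a carbonyl group. Among the measured compounds shown here, no measured step isolates this ester change; compound 2 and compound 3 differ in two places at once, and their values sit within the scatter of each other. Compound 1 and compound 2 already carry the cyclobutylmethyl ester and give low numbers.

The step of a number 3 percentage points lower from compound 3 to compound 4 (within the scatter) is therefore expected to show no change beyond the scatter. Compound 4 is estimated at 4%, with a range from -5% to 13%.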

Compound 4, a percentage reported as inhibition, at one concentration (the size of the read-out at that concentration, not a potency): 2%
Estimate against measurement, compound 4: 2 percentage points above; measured number inside the range.
By their numbers in this assay, from the lowest: compounds 1, 2, 4 and 3 (each within the scatter of the next).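

In this assay the ester change reads a number 5 percentage points lower from compound 3 to compound 4 (within the scatter) and thus isolates cyclobutylmethyl in place of sec-butyl on an oxygen next to a carbonyl group, with no change beyond the scatter. With the cyclobutylmethyl ester held, the step of no change at the digits printed from compound 2 to compound 4 (within the scatter) and the step of a number 1 percentage points higher from compound 1 to compound 4 (within the scatter) place thiophen-3-yl within the scatter of both furan groups on a saturated ring carbon. No evidence bears on these results.

Still open, from the compounds shown here alone, is whether a longer chain or an amine in place of cyclobutylmethyl would give a step beyond the scatter.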